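Compound 3 and its ring-closed relative, compound 4

The source may report more compounds than this note shows. Statements on the series, on what has been measured and on what is new or still open speak of the compounds shown alone.

In a functional assay on HT-1080 cells (Homo sapiens) for inhibition, read by sulforhodamine B assay, with a stated time of 48 h (on this read-out lower numbers stand for stronger inhibition and higher numbers for weaker inhibition), compound 1 `CCNC(=O)Nc1ccc(/C=C/c2cccc(Cl)c2)cc1` gives > 20000 nM, which is a limit and not a number. Compound 2 `CCNC(=O)Nc1ccc(/C=C\c2cccc(Cl)c2)cc1` gives 31000 nM, and compound 3 `CCNC(=O)Nc1ccc(/C=C\c2cc(C)cc(C)c2)cc1` gives 15000 nM. Compound 3 therefore holds the lower of the two actual numbers, and the gap between them lies just beyond the scatter.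

Compound 4 `Cc1cc(C)cc(/C=C\c2ccc(N3CCNC3=O)cc2)c1` has not yet been measured. It carries 2-oxoimidazolidin-1-yl in place of (ethylcarbamoyl)amino on an aromatic carbon, so the open chain gives way to a five-membered non-aromatic ring.

Within the data shown here, the one step measured, a step that the limit leaves unreadable from compound 1 to compound 2, has no readable size, and it concerns (the fact that compounds 1 and 2 differ only in the configuration as drawn), not the group changing here. Among the measured compounds shown here, no measured step therefore bears on this swap, and the expectation starts from compound 3 at 15000 nM. The expected result is no change at the digits printed from compound 3 to compound 4 (within the scatter), with no shift in either direction beyond the scatter. For compound 4 the estimate is 15000 nM, with an expected range from 5000 nM to 40000 nM.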

Compound 4, half-maximal inhibitory concentration: 15 nM
Compound 4: the middle estimate sits 1000-fold (3.00 log units) above what was measured, outside the stated range (below it).
By their numbers in this assay, from the lowest: compound 4; then compound 3; then compound 2.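

In this assay the group at this position turns out to matter very much, with a large step of a 1000-fold lower number from compound 3 to compound 4 (3.00 log units; beyond the scatter) on the aromatic carbon para to a large group. The earlier compounds shown here gave no sign of this, and the size of the step stands out. Both (ethylcarbamoyl)amino and 2-oxoimidazolidin-1-yl hold 6 heavy atoms: 2-oxoimidazolidin-1-yl adds a five-membered non-aromatic ring and has 1 hydrogen-bond donor where (ethylcarbamoyl)amino has 2. Nothing available here explains the step.

The compounds shown leave open whether the ring itself or the loss of a hydrogen-bond donor goes with the lower number. A six-membered cyclic urea, or a methyl group on the remaining ring nitrogen of 2-oxoimidazolidin-1-yl, would help to separate the two.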